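The source may report more compounds than this note shows. Statements on the series, on what has been measured and on what is new or still open speak of the compounds shown alone.

Measured compounds:
- compound 1, `COc1ccc(-c2cc(/C=C/C(=O)c3ccc(N)cc3)[nH]n2)cc1`, giving 101% in a functional assay on NCI-H460 cells (Homo sapiens) for cytotoxicity, read by sulforhodamine B assay, with a stated time of 48 h, tested at 0.01 uM; on this read-out lower numbers stand for a stronger effect and higher numbers for a weaker effect at the one concentration tested
- compound 2, `COc1cc(-c2cc(/C=C/C(=O)c3ccc(N)cc3)[nH]n2)cc(OC)c1OC`, giving 102% in this assay
- compound 3, `COc1ccc(C(=O)/C=C/c2cc(-c3cc(OC)c(OC)c(OC)c3)n[nH]2)cc1OC`, giving 103% in this assay

Compound 2 stands second highest of these three numbers in this assay, with compound 1 one step lower and compound 3 one step higher, both gaps within the usual scatter, so all three read as the same. Compound 4, `COc1ccc(-c2cc(/C=C/C(=O)c3ccc(N)cc3)[nH]n2)cc1OC`, is not yet measured; it differs from compound 2 in that (hydrogen in place of methoxy on an aromatic carbon). For the measured compounds named here, the only step measured so far, a number 1 percentage points higher from compound 2 to compound 3 (within the scatter), changes a different part of the molecule and was itself within the scatter, so it offers no direct guide to the change at hand. Going by the values given here, no measured pair shows a methoxy leaving this ring. Among the compounds with values here, with every number so far sitting together and no step beyond the scatter, compound 4 is expected to behave like compound 2, with a step of a number 1 percentage points lower from compound 2 to compound 4 (within the scatter). Compound 4 is therefore estimated at 101%, within the range 90% to 110%.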

Compound 4, a percentage reported as activity, at one concentration (the size of the read-out at that concentration, not a potency): 101%
The estimate for compound 4 equals the measured number at the digits printed, within the range that was stated.
By their numbers in this assay, from the lowest: compounds 1, 4, 2 and 3 (each within the scatter of the next).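

For the compounds shown here, replacing methoxy with hydrogen on this aromatic ring gives a number 1 percentage points lower from compound 2 to compound 4 (within the scatter), the first measured step at this ring. Placing methoxy on an aromatic carbon of the same ring, in place of hydrogen, gives no change at the digits printed from compound 1 to compound 4 (within the scatter), so neither single-place pair shows a difference that can be read in this assay at the one concentration tested. Nothing available explains why this exchange of methoxy and hydrogen leaves the number within the scatter.

Because all of these numbers sit together, this concentration cannot show whether the methoxy matters at a concentration where the compounds give a stronger effect. Also open, from the compounds shown here alone, is how a hydroxyl, a chlorine or an amine on this aromatic carbon would read in this assay.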